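The compounds below may be only part of what the source reports. "The series", "measured", "known", "first", "only" and "open" are said of these compounds alone.

Measured compounds:
Compound 1, `COc1cc[nH]c1/C=C1\C(=O)Nc2ccc(F)c(I)c21`, in a functional assay on MDA-MB-435 cells (Homo sapiens) for inhibition (a lower number here means a stronger inhibitor, a higher number a weaker inhibitor), gives only a limit, > 30000 nM.
Compound 2, `CN[C@H](C#Cc1c(F)ccc2c1/C(=C/c1[nH]ccc1OC)C(=O)N2)[C@@H](C)O`, in this assay gives 358 nM.
Compound 3, `COc1cc[nH]c1/C=C1\C(=O)Nc2ccc(F)c(C#C[C@@H]3CCCN3)c21`, in this assay gives 31 nM.

Compound 1 stands at the weak end of what has been shown: in this assay its result is a limit of the assay rather than a number, and it is the limit of > 30000 nM in this assay, at which 1 of the 3 values shown sits. The compound yet to be measured is compound 4, `COc1cc[nH]c1/C=C1\C(=O)Nc2ccc(F)c(C#C[C@@H]3C[C@H](O)CN3)c21`. It differs from compound 1 in one place: 2-(4-hydroxypyrrolidin-2-yl)ethynyl in place of iodo on an aromatic carbon.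

Among the compounds with values here, two measured steps bear on this change, both starting from compound 1 and both replacing the iodo group with a substituted ethynyl chain. There was an at least 83-fold lower number from compound 1 to compound 2 (1.92 log units; beyond the scatter), and there was an at least 960-fold lower number from compound 1 to compound 3 (2.98 log units; beyond the scatter). Between those two products there was a 12-fold lower number from compound 2 to compound 3 (1.06 log units; beyond the scatter), so the chain ending in pyrrolidin-2-yl gave the lower number of the two. Compound 4 carries that same pyrrolidine ring with a hydroxy group added to it. Because compound 3 sits at 31 nM while compound 2 sits at 358 nM, the step expected for compound 4 is an at least 600-fold lower number from compound 1 to compound 4 (2.77 log units; beyond the scatter). In this assay compound 4 is therefore estimated at about 50 nM, with a range from 15 nM to 200 nM.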

Compound 4, half-maximal inhibitory concentration: 110 nM
Estimate against measurement, compound 4: 2.2-fold (0.34 log units) below; measured number inside the range.
By their numbers in this assay, from the lowest: compound 3; then compound 4; then compound 2. At a limit, above all of these: compound 1.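

In this assay, the 2-(4-hydroxypyrrolidin-2-yl)ethynyl group, on the aromatic carbon ortho to a fluoro group, retains most of what the earlier ethynyl chains gained over iodo, with an at least 270-fold lower number from compound 1 to compound 4 (2.43 log units; beyond the scatter). The result for compound 1 is a limit of the assay and not a number, so the size of that step is only a bound: the limit of > 30000 nM in this assay, at which 1 of the 4 values shown sits. What is new is a comparison confined to the pyrrolidine ring, where adding hydroxy to a saturated ring carbon gives a 3.5-fold higher number from compound 3 to compound 4 (0.55 log units; beyond the scatter), a modest change, while the hydroxylated ring still compares favourably with the open chain, with a 3.3-fold lower number from compound 2 to compound 4 (0.51 log units; beyond the scatter).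

The compounds shown leave open whether this rise in the number is specific to hydroxy or would also follow a methoxy group, a fluoro group or an amine on the same ring carbon, and whether the opposite arrangement at the hydroxy-bearing carbon would give a different number. They also leave open how a six-membered piperidine ring at the end of the ethynyl chain would compare with the five-membered ring.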